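The source may hold more compounds than are shown below. What is called first, only, known or untested is meant among the compounds shown, and "the series" means these compounds.

Measured so far in a functional assay on MGC-803 cells (Homo sapiens) for inhibition, read by MTT assay, with a stated time of 72 h; a higher number here means a weaker inhibitor, a lower number a stronger inhibitor:
compound 1 `CC(C)n1ncc2c(C(=O)Nc3ccccc3)cccc21` gives 38500 nM.
Compound 2 `CC(C)n1ncc2c(C(=O)Nc3cccnc3)cccc21` gives > 40000 nM, a limit of the assay.
Compound 3 `CC(C)n1ncc2c(C(=O)NCc3cn(-c4ccc(F)cc4)nn3)cccc21` gives > 40000 nM, also a limit of the assay.

Compound 3 therefore stands with no number at all in this assay, only a limit, and it shares that position with compound 2, as the limit of > 40000 nM in this assay, at which 2 of the 3 values shown sit, shows. Compound 1 is the only one of the three with a measured number, and it is a high one.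

Among the measured compounds shown here, the single step with both ends measured is an at least 1.0-fold higher number from compound 1 to compound 2 (0.01 log units; that floor lies within the scatter); it concerns the group on the amide-type nitrogen and runs from a weak number into the limit, so it tells little about size and nothing about the other end of the molecule.

Compound 4 `Cc1ccccc1-n1cc(CNC(=O)c2cccc3c2cnn3C(C)C)nn1` differs from compound 3 by 2-methylphenyl in place of 4-fluorophenyl on an aromatic nitrogen. For the measured compounds named here, no measured step touches this position, and the step from compound 1 to compound 2 bears on a different place. With compound 3 at the limit and nothing in the series pointing to a gain, the expectation for compound 4 is a number at or near the limit again, that is, a step of about a number no higher from compound 3 to compound 4 (the limit leaves the size open), none beyond the scatter.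

Compound 4 is estimated at 40000 nM, with a range of 15000 nM to 90000 nM.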

Compound 4, half-maximal inhibitory concentration: > 40000 nM
Compound 4 gave a limit, no number; the forecaster's own chance of this, stated with the estimate: 60%; the middle value lies on the limit itself.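

In this assay, among the compounds shown here, compound 3 and compound 4 both end at a limit, so no step between them can be read and the exchange of 4-fluorophenyl for 2-methylphenyl stays without a size: the limit of > 40000 nM in this assay, at which 3 of the 4 values shown sit. The compounds shown leave open whether any group on the aromatic nitrogen, or any other change to the shared core, gives a number clearly stronger than that of compound 1.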